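A Third Methoxy Group on the Shared Core

A few compounds are considered here, and "the series" means these few. Any claim that something is new, unique, unknown or untested is made for them only; others in the source may bear on it.

Compound 1 `COc1ccc(-c2cc(/C=C/C(=O)c3ccc(N)cc3)[nH]n2)cc1OC` gives 4530 nM in a functional assay on NCI-H460 cells (Homo sapiens) for inhibition, read by sulforhodamine B assay, with a stated time of 48 h; on this read-out lower numbers stand for stronger inhibition of growth and higher numbers for weaker inhibition of growth.
Compound 2 `COc1ccc(-c2cc(/C=C/C(=O)c3cc(OC)c(OC)c(OC)c3)[nH]n2)cc1OC` gives 3600 nM in this assay.
Compound 3 `COc1ccc(C(=O)/C=C/c2cc(-c3cc(OC)c(OC)c(OC)c3)n[nH]2)cc1` gives 3750 nM in this assay.

The three measured numbers lie close together, and compound 2, though it carries the lowest of them, sits within the scatter of both compound 1 and compound 3, so no order among them can be read. Compound 4 `COc1cc(C(=O)/C=C/c2cc(-c3cc(OC)c(OC)c(OC)c3)n[nH]2)cc(OC)c1OC` differs from compound 2 by a single change: methoxy in place of hydrogen on an aromatic carbon. Among the measured compounds shown here, no measured pair shows what such a change does on this core, so there is nothing to anchor a direction. Given how flat the three numbers are, the step in this assay is expected to stay within the scatter, with no clear direction. Compound 4 is therefore estimated at 3600 nM, between 1500 nM and 8500 nM, an expected step of no change at the digits printed from compound 2 to compound 4 (within the scatter).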

Compound 4, concentration for total growth inhibition: 4330 nM
Estimate against measurement, compound 4: 1.2-fold (0.08 log units) below, and the stated range covers the measured number.
By their numbers in this assay, from the lowest: compounds 2, 3, 4 and 1 (each within the scatter of the next).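

Methoxy in place of hydrogen on an aromatic carbon, ortho to a methoxy group and meta to a large group, gives a 1.2-fold higher number from compound 2 to compound 4 (0.08 log units; within the scatter) in this assay. Among the compounds shown here, this is the first single-place step measured on the shared core, and it shows that this position accepts the added methoxy without a readable change in growth inhibition. Nothing measured here offers an explanation for this result.

On these data alone, whether an amine, a hydroxyl group or a longer chain such as ethoxy on this carbon would produce a step beyond the scatter remains open.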